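The source may report more compounds than this note shows. Statements on the series, on what has been measured and on what is new or still open speak of the compounds shown alone.

Measured compounds:
compound 3 `Cc1nn(-c2ncnc3nc[nH]c23)c2c1C(OCc1ccccc1Cl)CC(=O)N2`: 47 nM
compound 2 `Cc1nn(-c2ncnc3nc[nH]c23)c2c1C(c1ccc(F)cc1Cl)CC(=O)N2`: 280 nM
compound 1 `Cc1nn(-c2ncnc3nc[nH]c23)c2c1C(OCC(=O)c1ccc(F)cc1)CC(=O)N2`: 973 nM

In a functional assay on HEK293 cells for agonist activity at G-protein coupled receptor 39 (Homo sapiens), read by scintillation proximity assay and inositol phosphate accumulation, with a stated time of 75 min (on this read-out lower numbers stand for an effect already at smaller amounts and higher numbers for an effect only at larger amounts of compound), compound 3 stands lowest of the three numbers: the nearest step, a 6.0-fold lower number from compound 2 to compound 3 (0.78 log units; beyond the scatter), and the furthest, a 21-fold lower number from compound 1 to compound 3 (1.32 log units; beyond the scatter), both lie beyond the scatter. Compound 4 `Cc1cc(C)n(CCOC2CC(=O)Nc3c2c(C)nn3-c2ncnc3nc[nH]c23)n1` changes the same position that the large step from compound 1 to compound 3 changed: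

(3,5-dimethyl-1H-pyrazol-1-yl)methyl in place of 2-chlorophenyl on a saturated chain carbon bound to an oxygen on a saturated carbon

Among the compounds with values here, only that step bears on the new change, and it shows this place sets the number strongly. Within the data shown here, no measured compound carries a heteroaromatic group there, so the direction is not fixed by the data; with the best-placed group removed, a modest rise is expected, as a 6.4-fold higher number from compound 3 to compound 4 (0.81 log units; beyond the scatter). Compound 4 is therefore estimated at 300 nM, within 60 nM to 2000 nM.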

Compound 4, half-maximal effective concentration: 2000 nM
Compound 4: the middle estimate sits 6.7-fold (0.82 log units) below what was measured, and the stated range covers the measured number.
By their numbers in this assay, from the lowest: compound 3; then compound 2; then compound 1; then compound 4.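

In this assay, (3,5-dimethyl-1H-pyrazol-1-yl)methyl on the saturated chain carbon bound to an oxygen gives a 43-fold higher number from compound 3 to compound 4 (1.63 log units; beyond the scatter) and a 2.1-fold higher number from compound 1 to compound 4 (0.31 log units; beyond the scatter), so this group sits above both others compared at this place. Compared with the group on the saturated ring carbon, there is a 7.1-fold higher number from compound 2 to compound 4 (0.85 log units; beyond the scatter), so all three earlier groups give lower numbers. No measurement shown accounts for these steps.

Compound 4 changes the ring and the chain together, so a 2-(2-chlorophenyl)ethyl group would be needed to separate them. On these data alone, how an amine or a carboxylic acid on this chain would read also remains open.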